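Aryl ether amides: fluoro versus hydrogen on the central ring

This account rests on a few compounds, and the source may have more. Where it says the series, first, only, none or still open, it means among the compounds named here.

Measured compounds:
compound 1, `CNC(=O)c1cc(Oc2ccc(NC(=O)c3cc(-c4ccc(Br)cc4)ncn3)cc2)ccn1`, > 100000 nM in a functional assay on A549 cells (Homo sapiens) for cytotoxicity, read by MTT assay, with a stated time of 72 h; on this read-out higher numbers stand for weaker inhibition and lower numbers for stronger inhibition
compound 2, `CNC(=O)c1cc(Oc2ccc(NC(=O)c3nccc(-c4ccc(OC)cc4)n3)cc2F)ccn1`, 16600 nM
compound 3, `CNC(=O)c1cc(Oc2ccc(NC(=O)c3cc(-c4ccc(Br)cc4)ncn3)cc2F)ccn1`, > 100000 nM

Compound 1 gives a value in this assay that is a limit of the assay and not a number, > 100000 nM. Compound 3 likewise returns only a limit, > 100000 nM. For the measured compounds named here, compound 2 is the one member of the series with a read number, 16600 nM. Compound 2 and compound 3 differ in more than one place, and the difference between the two cores is not broken down here.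

Between compound 3 and compound 1 the change is hydrogen in place of fluoro on an aromatic carbon. The step that the two limits leave unreadable from compound 3 to compound 1 cannot be read, because the limit of > 100000 nM in this assay, at which 2 of the 3 values shown sit, holds both ends of it.

Compound 4, `CNC(=O)c1cc(Oc2ccc(NC(=O)c3nccc(-c4ccc(OC)cc4)n3)cc2)ccn1`, is not yet measured. Its relation to compound 2 is hydrogen in place of fluoro on an aromatic carbon, the same change as that from compound 3 to compound 1, at the same place: on an aromatic carbon of a six-membered aromatic ring of carbon only, ortho to a (2-(methylcarbamoyl)pyridin-4-yl)oxy group, meta to a large group. Going by the values given here, the one earlier instance of the change gives no readable size, so the expectation for compound 4 rests on the measured value of compound 2, 16600 nM, with the step treated as neutral within the usual scatter. The step from compound 2 to compound 4 is expected to be a 1.1-fold higher number from compound 2 to compound 4 (0.04 log units; within the scatter) in this assay. Compound 4 is therefore estimated at 18000 nM, between 6000 nM and 55000 nM.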

Compound 4, half-maximal inhibitory concentration: 11100 nM
Compound 4: middle estimate off by 1.6-fold (0.21 log units), on the high side; low and high end bracket the measured number.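

In this assay, hydrogen in place of fluoro on an aromatic carbon gives a 1.5-fold lower number from compound 2 to compound 4 (0.17 log units; within the scatter), so on the core of compound 2 the change cannot be told from repeat-measurement scatter. On the core of compound 3, the same change cannot be read, because compound 3 and compound 1 both return a limit of the assay and not a number: the limit of > 100000 nM in this assay, at which 2 of the 4 values shown sit. The series therefore offers one readable instance of the change, which shows a step within the scatter on one core but does not show that the same holds on the core of compound 3 or on any other core.

The compounds shown leave open whether another group on that aromatic carbon, such as chloro, methyl or an amine, would read differently from fluoro and hydrogen on the core of compound 2. Also open is which difference between the two cores matters: compound 2 and compound 3 differ in more than one place, and the pairs shown do not separate the methoxy group from the bromo group on a single core.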